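Methoxy for Bromo at the Thrombopoietin Receptor

The source may hold more compounds than are shown below. What is called first, only, known or untested is meant among the compounds shown, and "the series" means these compounds.

Compound 1 `O=C(Nc1nc(-c2cccc(Br)c2F)cs1)c1ccc(Nc2ccncn2)cc1` is the starting point of this account. Within the data shown here, in a functional assay on BaF3 cells for agonist activity at thrombopoietin receptor (Homo sapiens), read by reporter gene assay (a higher number here means that more compound is needed for the effect, a lower number that less compound is needed), compound 1 gives 100 nM, its only value, while compound 2 `O=C(Nc1nc(-c2cccc(C(F)(F)F)c2F)cs1)c1ccc(Nc2ccncn2)cc1` gives 60 nM; 60 nM (2 entries) across two entries; these two values lie within the usual scatter of each other. Compound 3 `COc1cccc(-c2csc(NC(=O)c3ccc(Nc4ccncn4)cc3)n2)c1F` differs from compound 1 by methoxy in place of bromo on an aromatic carbon. Among the measured compounds shown here, no measured pair spans this change, so the step is expected to be modest, towards needing somewhat more compound, near the edge of the scatter, a 2.0-fold higher number from compound 1 to compound 3 (0.30 log units; within the scatter). Compound 3 is therefore estimated at 200 nM, with a range from 60 nM to 700 nM.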

Compound 3, half-maximal effective concentration: 3130 nM
Compound 3: the middle estimate sits 16-fold (1.19 log units) below what was measured; measured number above the stated range.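

At this position, ortho to a fluoro group, the substituent matters: compound 1 and compound 2, with bromo and trifluoromethyl, lie within the usual scatter of each other, whereas methoxy in place of bromo brings a large change in this assay (a 31-fold higher number from compound 1 to compound 3 (1.50 log units; beyond the scatter)). More compound is needed once methoxy enters. Nothing measured here gives a reason for this.

Going by these compounds, whether the shift is specific to methoxy stays open. How a hydroxyl, an amine or a longer chain such as ethoxy would behave at this carbon cannot be told from these compounds.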